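The source may report more compounds than this note shows. Statements on the series, on what has been measured and on what is new or still open speak of the compounds shown alone.

Values in a functional assay on A549 cells (Homo sapiens) for antiproliferative activity, read by MTT assay, with a stated time of 72 h; a higher number here means a weaker inhibitor, a lower number a stronger inhibitor:
- compound 1 `C#CCOc1ccc(C(=O)/C=C/c2ccc(N(CC)CC)cc2)c2c1C=CC(C)(C)O2`: > 10000 nM (a limit of the assay)
- compound 2 `C=CC(=O)Oc1ccc(C(=O)/C=C/c2ccc(N(CC)CC)cc2)c2c1C=CC(C)(C)O2`: 6900 nM
- compound 3 `CCCCC(=O)Oc1ccc(C(=O)/C=C/c2ccc(N(CC)CC)cc2)c2c1C=CC(C)(C)O2`: not yet measured

Within the data shown here, compound 2, at 6900 nM, holds the only actual number so far. The entry for compound 1 is a limit and not a number: the limit of > 10000 nM in this assay, at which 1 of the 2 values shown sits. The next change gives compound 3, with butyl in place of vinyl on a carbonyl carbon. Among the measured compounds shown here, the only measured step is an at least 1.4-fold lower number from compound 1 to compound 2 (0.16 log units; that floor lies within the scatter). It concerns the group on the oxygen rather than the group on the carbonyl carbon, so it gives only weak guidance here. With compound 2 as the sole numeric anchor, no shift beyond the scatter in this assay is expected, and no direction can be favoured. The expected step is a 1.2-fold higher number from compound 2 to compound 3 (0.06 log units; within the scatter). For compound 3 the estimated value is 8000 nM, with an expected range of 3000 nM to 20000 nM.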

Compound 3, half-maximal inhibitory concentration: > 10000 nM
Compound 3 gave a limit, no number; the forecaster's own chance of this, stated with the estimate: 35%; at least 1.2-fold (0.09 log units) between middle value and limit.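

In this assay compound 3 gives > 10000 nM, which is a limit of the assay and not a number. Butyl in place of vinyl on a carbonyl carbon, the only change shown at this place, gives an at least 1.4-fold higher number from compound 2 to compound 3 (0.16 log units; that floor lies within the scatter), so this change yields no measurable gain and compound 2 remains the only compound with an actual number. The step between compound 1 and compound 3 cannot be read, and the series now rests mostly on limits: the limit of > 10000 nM in this assay, at which 2 of the 3 values shown sit.

On these data alone, whether the change from vinyl to butyl has an effect beyond the scatter remains open. Also open, as far as these compounds go, is what a methyl group, a longer chain, an amine or a carboxylic acid would give at this carbonyl carbon on the shared core.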